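The compounds below may be only part of what the source reports. "The series", "measured", "known", "first", "only" and "open" are said of these compounds alone.

Compound 1 `CC1=C(C(=O)C2CC2)C(c2ccco2)NC(=O)N1`: 7%
Compound 2 `CCSC(=O)C1=C(C)NC(=O)NC1c1ccco1`: 14%
Compound 3 `CCC(C)OC(=O)C1=C(C)NC(=O)NC1c1ccco1`: 3%

Three compounds sharing one core were tested in an assay on membranes from HeLa cells for displacement of a labelled ligand from adenosine receptor A3 (Homo sapiens), read by scintillation counting, with a stated time of 180 min, tested at 1 uM; a lower number here means less inhibition, a higher number more inhibition at the concentration tested (going by the name of the read-out). Compound 1 gives 7%, compound 2 gives 14% and compound 3 gives 3%. Compound 3 carries the lowest of the three numbers, but its gap to compound 1 is within the scatter a number 4 percentage points lower from compound 1 to compound 3 (within the scatter), while its gap to compound 2 is beyond it a number 11 percentage points lower from compound 2 to compound 3 (beyond the scatter). The step from compound 1 to compound 2 is within the scatter a number 7 percentage points higher from compound 1 to compound 2 (within the scatter).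

The next compound, compound 4 `CC1=C(C(=O)OC2CCCC2)C(c2ccco2)NC(=O)N1`, differs from compound 3 in one place:
cyclopentyl in place of sec-butyl on an oxygen next to a carbonyl group
Among the measured compounds shown here, none of the measured steps exchanges one alkyl group for another on this oxygen; the only step touching this position is the change from ethylsulfanyl to sec-butoxy, which was modest a number 11 percentage points lower from compound 2 to compound 3 (beyond the scatter). Since the alkyl groups on carbon or oxygen in compounds 1 and 3 gave numbers within the scatter of each other, no step beyond the scatter is expected in this assay from cyclopentyl in place of sec-butyl on an oxygen next to a carbonyl group. Compound 4 is therefore estimated at 6%, with a range from -5% to 20%, meaning an expected step of a number 3 percentage points higher from compound 3 to compound 4 (within the scatter).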

Compound 4, a percentage reported as inhibition, at one concentration (the size of the read-out at that concentration, not a potency): 14%
Compound 4: middle estimate off by 8 percentage points, on the low side; measured number inside the range.
By their numbers in this assay, from the lowest: compounds 3, 1, 2 and 4 (each within the scatter of the next, the first and the last beyond it).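

In this assay, among the compounds shown here, the exchange of sec-butyl for cyclopentyl on an oxygen next to a carbonyl group is the only step here between two alkyl groups at this oxygen, and it gives a number 11 percentage points higher from compound 3 to compound 4 (beyond the scatter), so the group on this oxygen can alone move the number beyond the scatter, though modestly. Cyclopentyloxy on the carbonyl carbon stands level with ethylsulfanyl, with no change at the digits printed from compound 2 to compound 4 (within the scatter), and its step from cyclopropyl, a number 7 percentage points higher from compound 1 to compound 4 (within the scatter), also stays within the scatter. Nothing given here bears on why sec-butyl and cyclopentyl differ.

On these data alone, whether a cyclohexyl ring, a straight butyl chain or an amide nitrogen in place of this oxygen would follow cyclopentyloxy or sec-butoxy remains open. With a single tested concentration, the potencies of these compounds also remain unknown.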